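This account rests on a few compounds, and the source may have more. Where it says the series, first, only, none or still open, it means among the compounds named here.

Notes on the series. Compound 2 `COc1cccc(N2C(=O)COc3ccc(-c4cnc(Cl)c(NS(=O)(=O)c5ccc(F)cc5)c4)cc32)c1` is taken as the reference point. In a functional assay on HCT-116 cells (Homo sapiens) for antiproliferative activity, read by MTT assay, with a stated time of 72 h (on this read-out lower numbers stand for stronger inhibition and higher numbers for weaker inhibition), compound 2 gives > 40000 nM, which is a limit of the assay and not a number. Compound 1 `COc1ccc(N2C(=O)COc3ccc(-c4cnc5ccccc5c4)cc32)cc1` likewise returns only a limit: in this assay compound 1 gives > 40000 nM. Among the compounds with values here, compound 3 `COc1cccc(N2C(=O)COc3ccc(-c4ccc(O)cc4)cc32)c1` is the one compound with a measured number in the set; in this assay compound 3 gives 15300 nM. Compound 2 thus stands at the limit of > 40000 nM in this assay, at which 2 of the 3 values shown sit, and no measured step between any two of these compounds is available to anchor the size of a structural change.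

Compound 4 `Cc1ccc(N2C(=O)COc3ccc(-c4cnc(Cl)c(NS(=O)(=O)c5ccc(F)cc5)c4)cc32)cc1` differs from compound 2 in one place: 4-methylphenyl in place of 3-methoxyphenyl on an amide-type nitrogen in a ring. On the numbers shown, no step beyond the usual scatter is expected in this assay from this change, in either direction. Compound 4 is therefore expected to remain at or near the assay limit, estimated at 50000 nM with a range from 20000 nM to 150000 nM. The step implied by that estimate, a step that the limit leaves unreadable from compound 2 to compound 4, is expected to lie within scatter.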

Compound 4, half-maximal inhibitory concentration: 34300 nM
The estimate for compound 4 lay 1.5-fold (0.16 log units) above the measured number; the measured number falls inside the stated range.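

Within the data shown here, with compound 4, the core of compound 2 gives a measured number for the first time: in this assay compound 4 gives 34300 nM. The readable change for 4-methylphenyl in place of 3-methoxyphenyl on the amide-type nitrogen in a ring is an at least 1.1-fold lower number from compound 2 to compound 4 (0.06 log units; that floor lies within the scatter), so the data show no step beyond the scatter at this position, but they set no upper bound on its size either. Compound 2 remains a limit of the assay and not a number, so only a floor can be read: the limit of > 40000 nM in this assay, at which 2 of the 4 values shown sit.

This single change alters both the group and where it sits on the phenyl ring, so the two cannot be separated here. As far as these compounds go, the effect of an amine or a carboxylic acid at this position also remains open.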